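The compounds below may be only part of what the source reports. "The series", "measured", "known", "first", "only" and "open" are said of these compounds alone.

Measured so far:
Compound 1, `CCCCCCCOc1cc(-c2ccccc2)c(-c2ccccc2)nn1`: 58000 nM
Compound 2, `CCCCCC[S+]([O-])c1cc(-c2ccccc2)c(-c2ccccc2)nn1`: 75000 nM

Going by the values given here, in an assay on microsomes from liver for inhibition of sterol O-acyltransferase 1 (Rattus norvegicus) (a higher number here means a weaker inhibitor, a lower number a stronger inhibitor), compound 2 gives the higher of the two numbers in hand, yet its only neighbour is compound 1, and the step of a 1.3-fold higher number from compound 1 to compound 2 (0.11 log units; within the scatter) lies within the scatter, so the two compounds cannot be ranked against each other on these data.

Compound 3, `CCCCCCCCC[S+]([O-])c1cc(-c2ccccc2)c(-c2ccccc2)nn1`, has not been measured. It differs from compound 2 by propyl in place of hydrogen on a saturated chain carbon, six bonds along the chain from a sulfur. Among the compounds with values here, no measured step changes the chain length; the one step known, a 1.3-fold higher number from compound 1 to compound 2 (0.11 log units; within the scatter), exchanges the ether group of compound 1 for the sulfoxide group of compound 2 at the aromatic carbon and is within the scatter. It therefore offers no direct guide for a longer chain, only the observation that a change of the same size at this part of the core left this assay unchanged.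

On that basis the step of a 1.3-fold lower number from compound 2 to compound 3 (0.10 log units; within the scatter) is expected to stay within the scatter, in no assured direction. Compound 3 is estimated at 60000 nM in this assay, with a range from 20000 nM to 200000 nM.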

Compound 3, half-maximal inhibitory concentration: 87000 nM
For compound 3 the middle estimate is 1.5-fold (0.16 log units) below the measured one; the range from low to high includes it.
By their numbers in this assay, from the lowest: compounds 1, 2 and 3 (each within the scatter of the next).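

The chain now has a measured step of its own in this assay: propyl in place of hydrogen on a saturated chain carbon, six bonds along the chain from a sulfur, gives a 1.2-fold higher number from compound 2 to compound 3 (0.06 log units; within the scatter) and so does not separate the two compounds. The earlier step changed only the group on the aromatic carbon, whereas this one leaves that sulfoxide in place and shows that a chain extended by propyl, as in compound 3 at 87000 nM, stays within the scatter of the shorter chain. No measurement in hand accounts for this result.

Still open, from the compounds shown here alone, is whether a longer chain than that of compound 3, or a chain ending in an amine or a carboxylic acid, would give a step beyond the scatter in this assay. Also open, going by these compounds, is whether a sulfone or a thioether at the aromatic carbon, or a substituent on either phenyl ring, would give a reading that differs from the sulfoxide compounds.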